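The source may hold more compounds than are shown below. What is called first, only, known or untested is meant among the compounds shown, and "the series" means these compounds.

Working notes on the series. In a functional assay, with a stated time of 150 min (on this read-out higher numbers stand for weaker inhibition and lower numbers for stronger inhibition), compound 1 (`CCOC(=O)c1cnn(-c2nc(-c3ccccc3O)c(C#N)c(=O)n2C)c1N`) gives 64 ug/mL, compound 2 (`CCOC(=O)c1cnn(-c2nc(-c3ccc(N(C)C)cc3)c(C#N)c(=O)n2C)c1N`) gives 115 ug/mL and compound 3 (`CCOC(=O)c1cnn(-c2nc(-c3ccco3)c(C#N)c(=O)n2C)c1N`) gives 108 ug/mL. Compound 3 stands within the scatter of both others, so the three numbers carry no order.

The next change leads to compound 4 (`CCOC(=O)c1cnn(-c2nc(-c3ccc(Cl)cc3)c(C#N)c(=O)n2C)c1N`), with 4-chlorophenyl in place of furan-2-yl on an aromatic carbon.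

All three measured steps exchange the group at this same place: a 1.8-fold higher number from compound 1 to compound 2 (0.25 log units; within the scatter), a 1.7-fold higher number from compound 1 to compound 3 (0.23 log units; within the scatter) and a 1.1-fold lower number from compound 2 to compound 3 (0.03 log units; within the scatter). The last of these is the nearest match, as it also links furan-2-yl with a substituted phenyl group. Going by the values given here, none of the three steps goes beyond the scatter, although the data hold no measured 4-chlorophenyl compound.

The expected outcome is a 1.1-fold lower number from compound 3 to compound 4 (0.03 log units; within the scatter), with no step in either direction expected beyond the scatter. Compound 4 is estimated at 100 ug/mL in this assay, with an expected range of 50 ug/mL to 200 ug/mL.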

Compound 4, half-maximal inhibitory concentration: 87 ug/mL
The estimate for compound 4 lay 1.1-fold (0.06 log units) above the measured number; the measured number falls inside the stated range.
By their numbers in this assay, from the lowest: compounds 1, 4, 3 and 2 (each within the scatter of the next).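

Replacing the furan-2-yl of compound 3, an oxygen-containing five-membered aromatic ring, with the carbon-only six-membered ring of 4-chlorophenyl leaves the number in this assay within the scatter (a 1.2-fold lower number from compound 3 to compound 4 (0.09 log units; within the scatter)). Going by these compounds alone, the same holds at the para-substituent of the phenyl ring, with chloro in place of dimethylamino (a 1.3-fold lower number from compound 2 to compound 4 (0.12 log units; within the scatter)), and against the 2-hydroxyphenyl group (a 1.4-fold higher number from compound 1 to compound 4 (0.13 log units; within the scatter)), so a chlorine-bearing aryl group on this carbon, ortho to the cyano group, fits the flat picture from the earlier compounds across these four compounds. No available evidence bears on this result.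

On these data alone, whether any group on this carbon can move the number beyond the scatter stays open, for example a carboxylic acid, a saturated amine such as piperidine or a longer alkyl chain. The compounds shown also leave open what changes elsewhere on the shared core would do, such as replacing the ethyl ester with a carboxylic acid.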